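Notes on the step to compound 4

The source may report more compounds than this note shows. Statements on the series, on what has been measured and on what is new or still open speak of the compounds shown alone.

- compound 1 `COc1cccc(/C=C2\CCC/C(=C\c3ccc(Cl)cc3)C2=O)c1OC` gives > 20000 nM (a limit)
- compound 2 `COc1cccc(/C=C2\CCC/C(=C\c3ccccc3Br)C2=O)c1OC` gives > 20000 nM (a limit)
- compound 3 `COc1cccc(/C=C2\CCC/C(=C\c3cccc(OC)c3OC)C2=O)c1` gives 16400 nM (a number)

All three values come from a functional assay on A549 cells (Homo sapiens) for cytotoxicity, read by MTT assay, with a stated time of 72 h (a higher number here means a weaker inhibitor, a lower number a stronger inhibitor), and only compound 3 has a true number, while the other two compounds stand at the limit of > 20000 nM in this assay, at which 2 of the 3 values shown sit, and are not ranked against it. The next structure is compound 4 `COc1cccc(/C=C2\CCC/C(=C\c3ccc(O)cc3)C2=O)c1OC`, reached through 4-hydroxyphenyl in place of 3-methoxyphenyl on a double-bonded chain carbon bound to a double-bonded ring carbon with 4-hydroxyphenyl in place of 3-methoxyphenyl on a double-bonded chain carbon bound to a double-bonded ring carbon.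

The measured steps at this place give little guidance. Both an at least 1.2-fold lower number from compound 1 to compound 3 (0.08 log units; that floor lies within the scatter) and an at least 1.2-fold lower number from compound 2 to compound 3 (0.08 log units; that floor lies within the scatter) are only floors, and a step that the two limits leave unreadable from compound 1 to compound 2 has no readable size. For the measured compounds named here, no measured compound carries 4-hydroxyphenyl. In this assay the expected change is therefore a 1.2-fold lower number from compound 3 to compound 4 (0.07 log units; within the scatter) and no shift beyond the scatter is foreseen, with a report at the limit still possible. For compound 4 the estimated value is 14000 nM within an expected range of 6000 nM to 30000 nM in this assay.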

Compound 4, half-maximal inhibitory concentration: > 20000 nM
Compound 4 ended at the assay's limit; the forecaster's own chance of this, stated with the estimate: 35%; middle value at least 1.4-fold (0.15 log units) away from the limit.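

In this assay, 4-hydroxyphenyl in place of 3-methoxyphenyl on a double-bonded chain carbon bound to a double-bonded ring carbon gives an at least 1.2-fold higher number from compound 3 to compound 4 (0.08 log units; that floor lies within the scatter). The entering group carries 1 hydrogen-bond donor against 0 hydrogen-bond donors in the leaving group, and this exchange yields no readable gain at this position. The steps to compound 4 from compound 1 and from compound 2 join two limits and cannot be read, and the series now rests mostly on a single ceiling: the limit of > 20000 nM in this assay, at which 3 of the 4 values shown sit.

As far as these compounds go, the true size of the change from 3-methoxyphenyl to 4-hydroxyphenyl stays open. Also open, from the compounds shown here alone, is whether an amine or a carboxylic acid in place of the hydroxy group would give a true number at this position.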